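Amide to carbamate on a piperidine nitrogen: permeability outlook

This account rests on a few compounds, and the source may have more. Where it says the series, first, only, none or still open, it means among the compounds named here.

Compound 1 `Cn1cncc1CN1CC(N(Cc2cccc(-n3cccc3)c2)S(=O)(=O)c2ccccn2)Cc2cc(C#N)ccc21`: 2.3 10^-6 cm/s
Compound 2 `CCCC(=O)N1CCC(CN(C2Cc3cc(C#N)ccc3N(Cc3cncn3C)C2)S(=O)(=O)c2ccccn2)CC1`: 0.5 10^-6 cm/s
Compound 3 `Cn1cncc1CN1CC(N(CC2CCN(S(C)(=O)=O)CC2)S(=O)(=O)c2ccccn2)Cc2cc(C#N)ccc21`: 0.1 10^-6 cm/s

Of the compounds shown here, three sharing one core have been measured in an ADME assay on Caco-2 cells (Homo sapiens) for permeability, in the apical to basolateral direction; a higher number here means that the compound crosses the layer faster, a lower number that the compound crosses the layer more slowly. Compound 1 gives the highest number, 2.3 10^-6 cm/s. Compound 2 stands second highest; the nearest measured compound is compound 1, with a 4.6-fold lower number from compound 1 to compound 2 (0.66 log units; beyond the scatter), and the furthest is compound 3, with a 5.0-fold lower number from compound 2 to compound 3 (0.70 log units; beyond the scatter). Compound 4 `CC(C)OC(=O)N1CCC(CN(C2Cc3cc(C#N)ccc3N(Cc3cncn3C)C2)S(=O)(=O)c2ccccn2)CC1` is not yet measured. It differs from compound 2 in one place: isopropoxy in place of propyl on a carbonyl carbon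

Within the data shown here, the step that bears most closely on this change is the one from compound 2 to compound 3, a 5.0-fold lower number from compound 2 to compound 3 (0.70 log units; beyond the scatter), where the whole propylcarbonyl group on the ring nitrogen was exchanged. Among the measured compounds shown here, the change to compound 4 keeps the carbonyl and only swaps propyl for isopropoxy, a smaller alteration than either measured step; no measured pair isolates this exchange. Compound 4 is therefore expected to stay close to compound 2, with an estimated step of no change at the digits printed from compound 2 to compound 4 (within the scatter), within the scatter. For compound 4 the estimate in this assay is 0.5 10^-6 cm/s, ranging from 0.2 10^-6 cm/s to 1.2 10^-6 cm/s.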

Compound 4, apparent permeability: 1 10^-6 cm/s
Beside the measured number, compound 4's estimate is 2.0-fold (0.30 log units) below it; low and high end bracket the measured number.
By their numbers in this assay, from the lowest: compound 3; then compounds 2 and 4 (each within the scatter of the next); then compound 1.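

In this assay, exchanging propyl for isopropoxy on the carbonyl carbon gives a 2.0-fold higher number from compound 2 to compound 4 (0.30 log units; within the scatter), so this first exchange at the position that keeps the carbonyl stays inside the scatter. Against methylsulfonyl on the amine nitrogen in a ring, isopropoxycarbonyl gives a 10-fold higher number from compound 3 to compound 4 (1.00 log units; beyond the scatter), which makes compound 4 a second carbonyl-bearing compound, after compound 2, that stands apart from compound 3, while the exchange of 3-(1H-pyrrol-1-yl)phenyl for 1-(isopropoxycarbonyl)piperidin-4-yl gives a 2.3-fold lower number from compound 1 to compound 4 (0.36 log units; beyond the scatter). Nothing available here bears on the cause of these differences.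

Going by these compounds, whether the oxygen and the branch of isopropoxy count separately on this carbonyl carbon stays open, and a straight propoxy or an isobutyl group there would separate the two. On these data alone, a dimethylamino group in the same place is equally open.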